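The source may report more compounds than this note shows. Statements on the series, on what has been measured and on what is new or still open speak of the compounds shown alone.

In a functional assay on LN-229 cells (Homo sapiens) for antiproliferative activity, with a stated time of 72 h (on this read-out lower numbers stand for stronger inhibition and higher numbers for weaker inhibition), compound 2 `Nc1ncnn2c([C@@H]3O[C@H](CO)[C@@H](O)[C@H]3O)cc(-c3ccccc3)c12` gives 75100 nM. Among the three measured compounds it holds the second highest number: compound 1 `Nc1ncnn2c([C@@H]3O[C@H](CO)[C@@H](O)[C@H]3O)cc(C#Cc3ccccc3)c12` gives 88000 nM, and a 1.2-fold lower number from compound 1 to compound 2 (0.07 log units; within the scatter), whereas compound 3 `Nc1ncnn2c([C@@H]3O[C@H](CO)[C@@H](O)[C@H]3O)cc(-c3ccc(Cl)cc3)c12` gives 32600 nM, and a 2.3-fold lower number from compound 2 to compound 3 (0.36 log units; beyond the scatter). Compound 4 `Nc1ncnn2c([C@@H]3O[C@H](CO)[C@@H](O)[C@H]3O)cc(-c3ccsc3)c12` carries thiophen-3-yl in place of phenyl on an aromatic carbon. Among the compounds with values here, the steps that bear on this are a 1.2-fold lower number from compound 1 to compound 2 (0.07 log units; within the scatter) and a 2.3-fold lower number from compound 2 to compound 3 (0.36 log units; beyond the scatter); neither one places a five-membered aromatic ring with 1 hetero atom on the shared core, and only the second of them moved the read-out beyond the scatter. Within the data shown here, with no measured step on a thiophen-3-yl, the expectation in this assay is a step that stays within the scatter, in either direction. Compound 4 is thus estimated at 70000 nM, with a range from 30000 nM to 160000 nM, which means an expected step of a 1.1-fold lower number from compound 2 to compound 4 (0.03 log units; within the scatter).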

Compound 4, half-maximal inhibitory concentration: 57700 nM
The estimate for compound 4 lay 1.2-fold (0.08 log units) above the measured number; low and high end bracket the measured number.
By their numbers in this assay, from the lowest: compounds 3, 4, 2 and 1 (each within the scatter of the next, the first and the last beyond it).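

In this assay, compound 4 puts a five-membered aromatic ring with 1 hetero atom on this aromatic carbon, and replacing phenyl with thiophen-3-yl gives a 1.3-fold lower number from compound 2 to compound 4 (0.11 log units; within the scatter). The other two steps, a 1.8-fold higher number from compound 3 to compound 4 (0.25 log units; within the scatter) and a 1.5-fold lower number from compound 1 to compound 4 (0.18 log units; within the scatter), also stay within the scatter, so compound 4 cannot be separated from any of the other three compounds, although compound 1 and compound 3 lie beyond the scatter of each other. Nothing available explains these numbers.

Going by these compounds, it remains open whether chloro on the thiophen-3-yl would lower the number as it did on the phenyl in a 2.3-fold lower number from compound 2 to compound 3 (0.36 log units; beyond the scatter). Also open, on these data alone, is what an amine or a carboxylic acid on this aromatic carbon would do to the read-out.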